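Notes on three measured analogues and one pending benzyl variant

The compounds below may be only part of what the source reports. "The series", "measured", "known", "first", "only" and "open" are said of these compounds alone.

Compound 1 `Cc1nn(-c2nc(-c3ccc(Cl)c(Cl)c3)c(SC(C)C)s2)c(C(=O)O)c1-c1cncnc1` gives 22000 nM in a functional assay on BJAB cells (Homo sapiens) for antiproliferative activity, with a stated time of 4 days; a higher number here means that more compound is needed for the effect, a lower number that less compound is needed.
Compound 2 `Cc1nn(-c2nc(-c3ccc(Cl)c(Cl)c3)c(SC(C)C)s2)c(C(=O)O)c1-c1cccc(C(F)(F)F)c1` gives 22000 nM in this assay.
Compound 3 `Cc1nn(-c2nc(-c3ccc(Cl)c(Cl)c3)c(SC(C)C)s2)c(C(=O)O)c1-c1cccnc1` gives 12000 nM in this assay.

Compound 3 holds the lowest of the three numbers, but the steps of a 1.8-fold lower number from compound 1 to compound 3 (0.26 log units; within the scatter) and a 1.8-fold lower number from compound 2 to compound 3 (0.26 log units; within the scatter) both lie within the scatter, so no order among the three can be claimed; the step of no change at the digits printed from compound 1 to compound 2 (within the scatter) likewise shows nothing beyond the scatter.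

Compound 4 `Cc1nn(-c2nc(-c3ccc(Cl)c(Cl)c3)c(SC(C)C)s2)c(C(=O)O)c1Cc1ccccc1[N+](=O)[O-]` is not yet measured. Its change from compound 3 is 2-nitrobenzyl in place of pyridin-3-yl on an aromatic carbon. The measured steps all exchange one six-membered aromatic ring for another at this same position, and every one of them stays within the scatter. Within the data shown here, none of them introduces a benzyl group or a nitro group, so no step bears directly on the change to compound 4. Given that the three swaps at this position left this assay unchanged within the scatter, the step of a 1.3-fold higher number from compound 3 to compound 4 (0.10 log units; within the scatter) is expected to stay within the scatter as well, with a wider uncertainty than for the measured swaps. Compound 4 is therefore estimated at 15000 nM, between 5000 nM and 50000 nM.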

Compound 4, half-maximal effective concentration: 20000 nM
For compound 4 the middle estimate is 1.3-fold (0.12 log units) below the measured one, and the stated range covers the measured number.
By their numbers in this assay, from the lowest: compounds 3, 4, 1 and 2 (each within the scatter of the next).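

Among these compounds, compound 4 brings a 2-nitrobenzyl group to this aromatic carbon, a change from the directly attached rings of the earlier compounds, and in this assay the comparisons give a 1.7-fold higher number from compound 3 to compound 4 (0.22 log units; within the scatter) and a 1.1-fold lower number from compound 2 to compound 4 (0.04 log units; within the scatter) and also a 1.1-fold lower number from compound 1 to compound 4 (0.04 log units; within the scatter) without any of them leaving the scatter. The position therefore shows no measurable response in these four compounds even when a benzyl group and a nitro group enter together, so the insensitivity seen among the aromatic ring swaps now extends to a larger substituent, and no order among compounds 1 to 4 can be claimed. No measurement at hand addresses why this position responds so little.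

Because the benzyl group and the nitro group arrive in a single change, the compounds shown cannot separate their contributions, and a plain benzyl group or a nitro group elsewhere on the benzyl ring would be needed for that. Going by these compounds, whether an amine, a carboxylic acid or a longer alkyl chain at this carbon would move the number beyond the scatter also remains open, as does the role of the carboxy and methyl groups held constant throughout.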